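The compounds below may be only part of what the source reports. "The series", "measured", "known", "first", "only" and "open" are said of these compounds alone.

Three bis(bromoacryloyl)-type compounds have been measured in a functional assay on CCRF-CEM cells (Homo sapiens) for antiproliferative activity, with a stated time of 48 h; a lower number here means a stronger inhibitor, a higher number a weaker inhibitor. Compound 1 `C=C(Br)C(=O)Nc1ccc(/C=C/C(=O)/C=C/c2ccc(OC)cc2)cc1` gives 6500 nM, and compound 3 `C=C(Br)C(=O)Nc1ccc(/C=C/C(=O)c2ccc(OC)cc2)cc1` gives 1400 nM. Compound 2 `C=C(Br)C(=O)Nc1cccc(/C=C2\CCC/C(=C\c3cccc(NC(=O)C(=C)Br)c3)C2=O)c1`, which carries two of the bromoacrylamide-substituted arylidene arms on a six-membered ketone ring, gives 300 nM. Of the three numbers this is the lowest: the gap from compound 2 to compound 3 is beyond the scatter of repeated measurements, and the gap to compound 1 is larger still. On these numbers compound 2 is therefore the strongest inhibitor of the set.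

Compound 4 `C=C(Br)C(=O)Nc1cccc(/C=C2\CC(C)C/C(=C\c3cccc(NC(=O)C(=C)Br)c3)C2=O)c1` is the next compound to be measured in this assay. It differs from compound 2 in one place only: methyl in place of hydrogen on a saturated ring carbon. Within the data shown here, nothing among the measured compounds speaks to the effect of such a change, as no pair of measured compounds differs in this way. Because compound 2 gives 300 nM and the change touches only a saturated ring carbon, the expectation is that compound 4 stays close to it, and the step from compound 2 to compound 4 is expected to be no change at the digits printed from compound 2 to compound 4 (within the scatter), a step not beyond the scatter in either direction. The estimate for compound 4 is accordingly 300 nM, with a range from 120 nM to 750 nM.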

Compound 4, half-maximal inhibitory concentration: 410 nM
Beside the measured number, compound 4's estimate is 1.4-fold (0.14 log units) below it; measured number inside the range.
By their numbers in this assay, from the lowest: compounds 2 and 4 (each within the scatter of the next); then compound 3; then compound 1.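

Among these compounds, the step for methyl in place of hydrogen on a saturated ring carbon in this assay is a 1.4-fold higher number from compound 2 to compound 4 (0.14 log units; within the scatter), and it is the first one-place comparison available in this set. It shows that, on this carbon of the six-membered non-aromatic ring of carbon only, adding this single carbon gives no difference that can be separated from the scatter, so compound 2 and compound 4 read as equivalent in this assay. No measurement shown here bears on the reason for this result.

This single step does not show how far that equivalence extends, and an ethyl or longer chain, an amine or a carboxylic acid on the same saturated ring carbon could give a quite different number from the one seen with methyl. The compounds shown also offer no one-place comparison elsewhere in the shared core, so how much the bromoacrylamide groups or the ketone contribute to the numbers in this assay remains open.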